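A few compounds are considered here, and "the series" means these few. Any claim that something is new, unique, unknown or untested is made for them only; others in the source may bear on it.

Compound 1 `CCn1c(C(=O)NCCN)ccc1C(CC)(CC)c1ccc(OCCC(O)(CC)CC)c(C)c1` gives 2940 nM in an ADME assay on L02 cells (Homo sapiens) for antiproliferative activity, read by MTT assay, with a stated time of 48 h; a lower number here means a stronger inhibitor, a higher number a weaker inhibitor.
Compound 2 `CCn1c(C(=O)Nc2ccc(OC(F)(F)F)cc2)ccc1C(CC)(CC)c1ccc(OCCC(O)(CC)CC)c(C)c1` gives > 50000 nM in this assay, which is a limit of the assay and not a number.

For the measured compounds named here, compound 1 holds the only number recorded in this assay. Compound 3 `CCOC(=O)CN(C)C(=O)c1ccc(C(CC)(CC)c2ccc(OCCC(O)(CC)CC)c(C)c2)n1CC` differs from compound 1 by ((ethoxycarbonyl)methyl)(methyl)amino in place of (2-aminoethyl)amino on a carbonyl carbon. Going by the values given here, the one measured step at the amide-type nitrogen, an at least 17-fold higher number from compound 1 to compound 2 (1.23 log units; beyond the scatter), ends at the limit named in the limit of > 50000 nM in this assay, at which 1 of the 2 values shown sits. Among the compounds with values here, compound 3 also gives up the (2-aminoethyl)amino group, so a higher number beyond the scatter is expected, though the measured step is the sole guide; the expected step is a 5.1-fold higher number from compound 1 to compound 3 (0.71 log units; beyond the scatter). Compound 3 is estimated at 15000 nM, with a range from 4000 nM to 60000 nM.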

Compound 3, half-maximal inhibitory concentration: 1990 nM
Beside the measured number, compound 3's estimate is 7.5-fold (0.88 log units) above it, and the stated range ends above it.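

In this assay, ((ethoxycarbonyl)methyl)(methyl)amino in place of (2-aminoethyl)amino on the carbonyl carbon gives a 1.5-fold lower number from compound 1 to compound 3 (0.17 log units; within the scatter), so losing the (2-aminoethyl)amino group does not by itself lead to the limit. The (4-(trifluoromethoxy)phenyl)amino group stands apart, with an at least 25-fold lower number from compound 2 to compound 3 (1.40 log units; beyond the scatter). The value of compound 2 is a limit and not a number: the limit of > 50000 nM in this assay, at which 1 of the 3 values shown sits.

Open, on these data alone, is whether a carboxylic acid in place of the ethyl ester of compound 3 keeps this level. Also open, as far as these compounds go, is whether an unsubstituted phenyl on the amide nitrogen follows compound 2.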